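Swapping the open amine chain for 4-aminocyclohexyl

This account rests on a few compounds, and the source may have more. Where it says the series, first, only, none or still open, it means among the compounds named here.

Measured so far in an ADME assay on microsomes from liver (Homo sapiens) for metabolic stability (on this read-out lower numbers stand for a less stable compound and higher numbers for a more stable compound), are these compounds
compound 1 `C/C(CN)=C(/F)CN(C[C@H]1Cc2ccccc2CN1)[C@H]1CCCc2cccnc21` gives 97%
compound 2 `C/C(=C/CN(C[C@H]1Cc2ccccc2CN1)[C@H]1CCCc2cccnc21)CN` gives 100%

Compound 2 stands at 100% and so level with compound 1 within the scatter, both close to the top of the scale. Compound 3 `N[C@H]1CC[C@H](CN(C[C@H]2Cc3ccccc3CN2)[C@H]2CCCc3cccnc32)CC1` is the next to read in this assay and has no number yet. Its change is a group of 7 heavy atoms (6 carbon, 1 nitrogen; one six-membered non-aromatic ring of carbon only) in place of a group of 5 heavy atoms (4 carbon, 1 nitrogen; no ring), on a saturated chain carbon bound to an amine nitrogen and amounts to 4-aminocyclohexyl entering, with 2 defined stereocentres, while the open chain with its double bond leaves. Going by the values given here, one measured step bears on this place, with a number 3 percentage points higher from compound 1 to compound 2 (within the scatter) as its size, and it stays within open chains, so no measured step shows what a ring does here. Compound 2 at 100% leaves little room upward, so a small downward step, or none beyond the scatter, is expected. The estimated step is a number 8 percentage points lower from compound 2 to compound 3 (within the scatter) on this thin evidence. Compound 3 is expected at 92% in this assay, with an estimated range of 72% to 100% for now.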

Compound 3, percent of the compound remaining: 39%
Compound 3: the middle estimate sits 53 percentage points above what was measured; measured number outside the range, below it.
By their numbers in this assay, from the lowest: compound 3; then compounds 1 and 2 (each within the scatter of the next).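

The position is not indifferent to its substituent: in this assay, 4-aminocyclohexyl in place of the open chain gives a number 61 percentage points lower from compound 2 to compound 3 (beyond the scatter), and in place of 2-(aminomethyl)-1-fluoroprop-1-en-1-yl it gives a number 58 percentage points lower from compound 1 to compound 3 (beyond the scatter), whereas the exchange between the two open chains gives only a number 3 percentage points higher from compound 1 to compound 2 (within the scatter). Going by these compounds alone, the large loss therefore accompanies the change from an open chain with a double bond to a six-membered carbon ring, though compound 3 is the only ring example here and the ring's entry and the double bond's departure cannot be separated. No available data bear on the reason for this loss.

A saturated open chain such as 4-aminobutyl would separate the loss of the double bond from the entry of the ring, while the other stereoisomer of 4-aminocyclohexyl would test the role of the defined stereocentres. Plain cyclohexyl and piperidin-4-yl would show whether the outcome depends on the primary amine on the ring or on the all-carbon ring.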